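The source may report more compounds than this note shows. Statements on the series, on what has been measured and on what is new or still open speak of the compounds shown alone.

Working notes on the series. The three measured compounds share one core and differ only in the group on a nitrogen on an aromatic ring. In an assay on mitochondria from L6 cells (Rattus norvegicus) for activation, with a stated time of 90 min (on this read-out higher numbers stand for an effect only at larger amounts of compound and lower numbers for an effect already at smaller amounts), compound 1 `Fc1ccc(Nc2nc3nonc3nc2Nc2ccccc2F)c(F)c1` gives 300 nM. Compound 2 `Cc1ccccc1Nc1nc2nonc2nc1Nc1ccccc1F` gives 1100 nM, a step of a 3.7-fold higher number from compound 1 to compound 2 (0.56 log units; beyond the scatter). Compound 3 `Cc1cccc(Nc2nc3nonc3nc2Nc2ccccc2F)c1` gives 1500 nM, the highest of the three numbers; the nearest step, a 1.4-fold higher number from compound 2 to compound 3 (0.13 log units; within the scatter), lies within the scatter, the furthest, a 5.0-fold higher number from compound 1 to compound 3 (0.70 log units; beyond the scatter), beyond it. Compound 4 `COc1ccc(Nc2nc3nonc3nc2Nc2ccccc2F)cc1` differs from compound 3 as follows: 4-methoxyphenyl in place of 3-methylphenyl on a nitrogen on an aromatic ring. Within the data shown here, no measured step puts 4-methoxyphenyl in place of 3-methylphenyl; the only step between the two methyl-bearing groups, a 1.4-fold higher number from compound 2 to compound 3 (0.13 log units; within the scatter), stayed within the scatter, while both steps away from compound 1 were modest. Compound 4 is therefore expected to stay near compound 3, an estimated step of no change at the digits printed from compound 3 to compound 4 (within the scatter). The estimate for compound 4 in this assay is 1500 nM, between 500 nM and 4500 nM.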

Compound 4, half-maximal effective concentration: 1600 nM
The estimate for compound 4 lay 1.1-fold (0.03 log units) below the measured number; low and high end bracket the measured number.
By their numbers in this assay, from the lowest: compound 1; then compounds 2, 3 and 4 (each within the scatter of the next).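

Among these compounds, with 4-methoxyphenyl, the only group here that carries oxygen, the number stays level with those of the methyl-bearing groups, at a 1.1-fold higher number from compound 3 to compound 4 (0.03 log units; within the scatter) and a 1.5-fold higher number from compound 2 to compound 4 (0.16 log units; within the scatter). This place therefore tolerates a hydrogen-bond acceptor in the group without a step beyond the scatter. Only 2,4-difluorophenyl stands apart, now also against 4-methoxyphenyl, with a 5.3-fold higher number from compound 1 to compound 4 (0.73 log units; beyond the scatter).

Open, going by these compounds, is how an amine or a carboxylic acid on the phenyl group would read, and whether the lower number of compound 1 needs both fluorines. Nothing available explains these numbers.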